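The source may hold more compounds than are shown below. What is called first, only, known or untested is meant among the compounds shown, and "the series" means these compounds.

Compound 1 `CCCn1cc(S(=O)(=O)c2ccc(CNC(=O)N3Cc4ccncc4C3)cc2)cn1` gives 17 nM in an assay on isolated protein for inhibition of Nicotinamide phosphoribosyltransferase (Homo sapiens), read by mass spectrometry, with stated times of 15 min and 30 min (on this read-out lower numbers stand for stronger inhibition and higher numbers for weaker inhibition), and stands lowest of the two numbers; compound 2 `CN1CCC(S(=O)(=O)c2ccc(CNC(=O)N3Cc4ccncc4C3)cc2)CC1` gives 48 nM there, and the step of a 2.8-fold higher number from compound 1 to compound 2 (0.45 log units; beyond the scatter) is modest but beyond the scatter. Compound 3 `O=C(NCc1ccc(S(=O)(=O)N2CCC[C@H](O)C2)cc1)N1Cc2ccncc2C1` carries the change (3-hydroxypiperidin-1-yl in place of 1-propyl-1H-pyrazol-4-yl on a sulfonyl sulfur). Going by the values given here, the only step that bears on it is the one from compound 1 to compound 2, which also put a six-membered non-aromatic ring on the sulfonyl sulfur in place of the 1-propyl-1H-pyrazol-4-yl and raised the number by a 2.8-fold higher number from compound 1 to compound 2 (0.45 log units; beyond the scatter). A loss of similar size is therefore expected, so the step is estimated as a 2.6-fold higher number from compound 1 to compound 3 (0.42 log units; beyond the scatter). Compound 3 is expected at 45 nM, with a range from 18 nM to 120 nM.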

Compound 3, half-maximal inhibitory concentration: 770 nM
Compound 3: the middle estimate sits 17-fold (1.23 log units) below what was measured, outside the stated range (above it).
By their numbers in this assay, from the lowest: compound 1; then compound 2; then compound 3.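

In this assay the sulfonyl sulfur does not accept every six-membered non-aromatic ring alike: 3-hydroxypiperidin-1-yl brings a 45-fold higher number from compound 1 to compound 3 (1.66 log units; beyond the scatter) and, set against 1-methylpiperidin-4-yl, a 16-fold higher number from compound 2 to compound 3 (1.21 log units; beyond the scatter) in the same direction. Ring size and the absence of aromaticity therefore do not settle the outcome at this position, since the two rings differ widely.

Open, going by these compounds, is whether the loss follows the hydroxyl or the attachment through the ring nitrogen; a plain piperidin-1-yl would separate the two. Nothing available speaks to the cause of this loss.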